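The source may hold more compounds than are shown below. What is called first, only, known or untested is meant among the compounds shown, and "the series" means these compounds.

The study collects three measured amines on one shared core, each carrying an aromatic group on a saturated chain carbon bound to the amine nitrogen, and tests them in an ADME assay on MDCK cells (Canis lupus familiaris) for cytotoxicity, read by microscopy, with a stated time of 48 h; on this read-out higher numbers stand for lower toxicity in this test and lower numbers for higher toxicity in this test. Compound 1, with structure `CCc1ccc(CN[C@@H]2C[C@H]3C[C@@H]([C@H]2C)C3(C)C)s1`, gives 1560 nM in this assay. Compound 2, with structure `CCCc1csc(CN[C@@H]2C[C@H]3C[C@@H]([C@H]2C)C3(C)C)c1`, gives 12500 nM in this assay. Compound 3, with structure `C[C@H]1[C@H](NCc2cnccn2)C[C@H]2C[C@@H]1C2(C)C`, is different: in this assay compound 3 gives only a limit of the test, > 100000 nM, and no number. Compound 3 therefore stands at the upper edge of what the test can report, as the limit of > 100000 nM in this assay, at which 1 of the 3 values shown sits, records, with the other two compounds at lower readings.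

The next compound, compound 4 with structure `Cc1n[nH]cc1CN[C@@H]1C[C@H]2C[C@@H]([C@H]1C)C2(C)C`, is not yet measured. It differs from compound 3 in one place: 3-methyl-1H-pyrazol-4-yl in place of pyrazin-2-yl on a saturated chain carbon bound to an amine nitrogen. For the measured compounds named here, since compound 3 sits at a limit, no counted step between measured compounds covers this change, and the expectation rests on compound 3 alone. The step of a number no higher from compound 3 to compound 4 (the limit leaves the size open) is expected to be none beyond the scatter of this assay. Compound 4 is thus expected to give about 100000 nM in this assay, with a likely range from 30000 nM to 300000 nM, and most probably again only a limit rather than a number.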

Compound 4, minimum cytotoxic concentration: > 100000 nM
Compound 4: a limit, no number (the forecaster's own chance of this, stated with the estimate: 60%); the middle value sits exactly at the limit.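

In this assay, compound 3 and compound 4 both give only a limit and no number, so no step can be read between them: the limit of > 100000 nM in this assay, at which 2 of the 4 values shown sit. The compounds shown leave open how far either reading lies past that limit, and whether 3-methyl-1H-pyrazol-4-yl in place of pyrazin-2-yl changes the reading at all.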